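Replacing a hydroxy on the double-bonded nitrogen of compound 1

This account rests on a few compounds, and the source may have more. Where it says the series, first, only, none or still open, it means among the compounds named here.

Measured so far in a functional assay on MCF7 cells (Homo sapiens) for antiproliferative activity, with a stated time of 5 days; on this read-out higher numbers stand for weaker inhibition and lower numbers for stronger inhibition:
compound 1, `CCCCc1ccc2[nH]c(-c3ccc(OC)cc3)c(/C=N/O)c2c1`, gives 212 nM
compound 2, `COc1ccc(-c2[nH]c3ccc(C)cc3c2/C=N/NC(=O)c2ccncc2)cc1`, gives 200 nM
compound 3, `CCCCc1ccc2[nH]c(-c3ccc(C(F)(F)F)cc3)c(/C=N/NC(=O)c3cccnc3)c2c1`, gives 260 nM

Compound 1 carries a hydroxy on a double-bonded nitrogen, whereas compound 2 and compound 3 each carry a carbonylamino group on that nitrogen. Among the three numbers, compound 1 sits between compound 2 and compound 3, and both of those neighbours lie within the usual scatter of compound 1, so the three compounds cannot be told apart in this assay.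

The next compound, compound 4, `CCCCc1ccc2[nH]c(-c3ccc(OC)cc3)c(/C=N/NC(=O)c3ccccn3)c2c1`, differs from compound 1 in one place: ((pyridin-2-yl)carbonyl)amino in place of hydroxy on a double-bonded nitrogen. Going by the values given here, no pair of measured compounds shows this change directly. What the set does show is that compound 2 and compound 3, which carry a group of the same kind in the same place, give numbers indistinguishable from compound 1. On that basis the step from compound 1 to compound 4 is expected to be small, in no particular direction, and not beyond the scatter, as a 1.0-fold higher number from compound 1 to compound 4 (0.02 log units; within the scatter) says. Compound 4 is therefore estimated at 220 nM in this assay, with a range from 100 nM to 500 nM.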

Compound 4, half-maximal inhibitory concentration: 160 nM
Estimate against measurement, compound 4: 1.4-fold (0.14 log units) above; the measured number falls inside the stated range.
By their numbers in this assay, from the lowest: compounds 4, 2, 1 and 3 (each within the scatter of the next).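

In this assay, the exchange of hydroxy for ((pyridin-2-yl)carbonyl)amino on a double-bonded nitrogen can now be read directly, as a 1.3-fold lower number from compound 1 to compound 4 (0.12 log units; within the scatter), and the two compounds cannot be told apart. The entering group has 9 heavy atoms and a six-membered aromatic ring with 1 hetero atom, whereas the leaving hydroxy has 1 heavy atom, so in this pair a much larger group on this nitrogen leaves the number within the scatter. Going by these compounds alone, compound 2 and compound 3 also differ from compound 1 elsewhere in the structure, which makes this the first pair to isolate a change at this position. Nothing measured on hand accounts for how close the two numbers stay.

Going by these compounds, it remains open whether a methoxy or a simple amine on the same nitrogen would also leave the number within the scatter. Also open, on these data alone, is whether a benzoylamino group, with a plain phenyl ring in place of the pyridine, would read the same on the core of compound 1.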